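Cell tolerance notes: the step from compound 3 to compound 4

This account rests on a few compounds, and the source may have more. Where it says the series, first, only, none or still open, it means among the compounds named here.

The series shares the core seen in compound 1 `COc1ccc([C@H]2CC(=O)N(c3ccccc3C#N)C2)cc1OC1CCCC1` and varies the group on the amide-type nitrogen in the ring. In a functional assay on HEK293 cells (Homo sapiens) for cytotoxicity (a lower number here means that less compound is tolerated, a higher number that more compound is tolerated), compound 1 gives > 10000 nM, which is a limit of the assay and not a number. Compound 2 `COc1ccc([C@H]2CC(=O)N(c3cccnc3)C2)cc1OC1CCCC1` carries pyridin-3-yl in place of 2-cyanophenyl there; in this assay compound 2 gives > 10000 nM, again only a limit. Hence a step that the two limits leave unreadable from compound 1 to compound 2. Among the measured compounds shown here, compound 3 `COc1ccc([C@H]2CC(=O)N(c3cccc(NCC4CCOC4)c3)C2)cc1OC1CCCC1` is the nearest precedent for the present step; in this assay compound 3 gives > 10000 nM, a limit and not a number. For the measured compounds named here, compound 3 thus sits where every value shown sits, at the limit of > 10000 nM in this assay, at which 3 of the 3 values shown sit, and no measured step in the set is readable in size.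

Compound 4 `COc1ccc([C@H]2CC(=O)N(c3cccc(NS(=O)(=O)c4cccc(F)c4)c3)C2)cc1OC1CCCC1` differs from compound 3 in one place: (3-fluorophenyl)sulfonyl in place of (oxolan-3-yl)methyl on a nitrogen on an aromatic ring. Going by the values given here, no measured step touches this nitrogen, and the only measured pair is unreadable, so nothing supports a shift in this assay beyond the scatter in either direction. The expectation is that compound 4 also stays at the limit, so a step that the limit leaves unreadable from compound 3 to compound 4 is expected. Compound 4 is estimated at 15000 nM, with a range from 5000 nM to 50000 nM.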

Compound 4, half-maximal cytotoxic concentration: > 10000 nM
Compound 4: only a limit was reported; the forecaster's own chance of this, stated with the estimate: 80%; the middle value does not contradict the limit.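

In this assay compound 4 gives > 10000 nM, a limit and not a number. The step from compound 3 to compound 4 therefore cannot be read in size, and all values shown stay at one place: the limit of > 10000 nM in this assay, at which 4 of the 4 values shown sit. The compounds shown leave open at what concentration any of the four becomes cytotoxic, and whether any change of group shifts that concentration.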